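Replacing Fluoro With Methoxy on an Azido Nucleoside

The source may report more compounds than this note shows. Statements on the series, on what has been measured and on what is new or still open speak of the compounds shown alone.

Of the compounds shown here, three of this set have been tested in an ADME assay on CCRF-CEM cells (Homo sapiens) for cytotoxicity, with a stated time of 5 days; a higher number here means a weaker inhibitor, a lower number a stronger inhibitor. Compound 1 `CNc1nc(Cl)nc2c1ncn2[C@H]1C[C@H](N=[N+]=[N-])[C@@H](CO)O1` gives only a limit, > 100000 nM, not a number. Compound 3 `C=CCNc1ncnc2c1ncn2[C@H]1C[C@H](N=[N+]=[N-])[C@@H](CO)O1` likewise gives only the limit of > 100000 nM. For the measured compounds named here, compound 2 `[N-]=[N+]=N[C@H]1C[C@H](n2cnc3c(N)nc(F)nc32)O[C@@H]1CO` is the one member that yields a number, 30100 nM, and it therefore stands as the sole reference point on this scale; the other two values sit at the limit of > 100000 nM in this assay, at which 2 of the 3 values shown sit.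

Compound 4 `COc1nc(N)c2ncn([C@H]3C[C@H](N=[N+]=[N-])[C@@H](CO)O3)c2n1` has not yet been measured. It differs from compound 2 in a single place: methoxy in place of fluoro on an aromatic carbon.

Going by the values given here, with no measured pair that makes the same change, there is no step here to lean on, and the size of the effect can only be guessed. The expectation is a modest weakening, of about a 2.0-fold higher number from compound 2 to compound 4 (0.30 log units; within the scatter), with a real chance that the result is only a limit again. Compound 4 is expected to give roughly 60000 nM, within 20000 nM to 100000 nM.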

Compound 4, half-maximal inhibitory concentration: > 100000 nM
Compound 4: a limit, no number; the forecaster's own chance of this, stated with the estimate: 35%; middle value at least 1.6-fold (0.22 log units) away from the limit.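

In this assay, putting methoxy in place of fluoro on the aromatic carbon between two ring nitrogen atoms gives an at least 3.3-fold higher number from compound 2 to compound 4 (0.52 log units; beyond the scatter). For the compounds shown here, this is the first measured change at this position, and it lies beyond the scatter, so what this carbon carries does matter for the read-out. Compound 4 gives a limit, not a number, so the change has a known lower bound but no known full size, and compound 2 remains the only compound on the measurable part of the scale: the limit of > 100000 nM in this assay, at which 3 of the 4 values shown sit.

A single pair cannot separate the loss of fluoro from the arrival of methoxy, so it remains unclear which of the two counts. As far as these compounds go, it also remains open whether an amine, a hydroxy group or a longer chain such as ethoxy at this carbon would give a number or another limit.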